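The compounds below may be only part of what the source reports. "The series", "measured", "known", "first", "only" and "open" are said of these compounds alone.

Measured so far in a functional assay on MCF7 cells (Homo sapiens) for inhibition, read by sulforhodamine B assay; on this read-out higher numbers stand for weaker inhibition and lower numbers for stronger inhibition:
- Compound 1 `O=C1C=C(N2CCC2)C(=O)c2c1nc1n2[C@H]2OC[C@@H](O)[C@H]2OC1`: > 16000 nM
- Compound 2 `O=C1C=C(Nc2ccc(Br)cc2)C(=O)c2c1nc1n2[C@H]2OC[C@@H](O)[C@H]2OC1`: 2580 nM

Compound 1 gives > 16000 nM, which is a limit of the assay and not a number. Going by the values given here, compound 2, at 2580 nM, holds the only numerical value so far.

The next compound is compound 3 `CCCN(CCC)C1=CC(=O)c2nc3n(c2C1=O)[C@H]1OC[C@@H](O)[C@H]1OC3`, and the change from compound 2 is dipropylamino in place of (4-bromophenyl)amino on a double-bonded ring carbon. Among the compounds with values here, one measured step bears on this, an at least 6.2-fold lower number from compound 1 to compound 2 (0.79 log units; beyond the scatter). It introduced the (4-bromophenyl)amino group, whereas the new change removes it, so the direction is taken from that step and reversed. Its size is open-ended, and dipropylamino is a different group from the azetidin-1-yl of compound 1, so only part of that step is expected to return.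

In this assay, the estimated change is a moderate move towards weaker inhibition, a 2.3-fold higher number from compound 2 to compound 3 (0.37 log units; beyond the scatter). Compound 3 is expected at 6000 nM, with an estimated range of 1800 nM to 18000 nM.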

Compound 3, half-maximal inhibitory concentration: > 16000 nM
Compound 3 ended at the assay's limit (the forecaster's own chance of this, stated with the estimate: 25%); middle value at least 2.6-fold (0.42 log units) from the limit.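

In this assay, exchanging (4-bromophenyl)amino for dipropylamino on the double-bonded ring carbon gives an at least 6.2-fold higher number from compound 2 to compound 3 (0.79 log units; beyond the scatter), so an open-chain dialkylamine does not retain the measurable value of compound 2. The result for compound 3 is a limit of the assay and not a number. The azetidin-1-yl of compound 1 and the dipropylamino of compound 3 therefore give the same outcome despite the ring in one and the two chains in the other, the step between them cannot be read, and among the three amino groups shown only (4-bromophenyl)amino gives a numerical value, with the other two compounds sharing one ceiling: the limit of > 16000 nM in this assay, at which 2 of the 3 values shown sit.

Going by these compounds, what remains open is which part of (4-bromophenyl)amino matters, since its departure removes the aromatic ring, the bromine and the hydrogen-bond donor together. Phenylamino without the bromine, 4-chlorophenylamino, or a secondary amine such as propylamino or benzylamino would begin to separate these features, and the limit leaves unresolved how far compound 1 and compound 3 lie from each other.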